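Dimethylamino for fluoro on a weak pyridinecarboxylic acid amide

This account rests on a few compounds, and the source may have more. Where it says the series, first, only, none or still open, it means among the compounds named here.

The account concerns two measured amides of a shared core and one that remains to be tested. In an assay on isolated protein (Gallus gallus) for inhibition of transmembrane prolyl 4-hydroxylase (Homo sapiens) (on this read-out higher numbers stand for weaker inhibition and lower numbers for stronger inhibition), compound 1, `O=C(Nc1ccccc1Cl)c1ccc(C(=O)O)nc1`, gives 16300 nM. In this assay compound 2, `O=C(Nc1ccc(F)cc1)c1ccc(C(=O)O)nc1`, gives 16100 nM, a number that sits together with that of compound 1, the gap between them lying within the scatter; on the two numbers shown, compound 2 therefore stands beside compound 1 rather than apart from it.

Compound 3, `CN(C)c1ccc(NC(=O)c2ccc(C(=O)O)nc2)cc1`, is the next step. Its difference from compound 2 is dimethylamino in place of fluoro on an aromatic carbon. Among the compounds with values here, no step between measured compounds speaks to this exchange, so the expectation rests on the two numbers at hand, which show the shared core with either substituent at the same weak level.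

The step from compound 2 to compound 3 is expected to be a 1.2-fold lower number from compound 2 to compound 3 (0.06 log units; within the scatter), which is to say none beyond the scatter in either direction. Compound 3 is accordingly estimated at 14000 nM in this assay, within a range of 5000 nM to 40000 nM.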

Compound 3, half-maximal inhibitory concentration: 4100 nM
Compound 3: middle estimate off by 3.4-fold (0.53 log units), on the high side; measured number below the stated range.
By their numbers in this assay, from the lowest: compound 3; then compounds 2 and 1 (each within the scatter of the next).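

In this assay, within the data shown here, dimethylamino in place of fluoro on an aromatic carbon, para to a large group, gives a 3.9-fold lower number from compound 2 to compound 3 (0.59 log units; beyond the scatter), the first step here to lie beyond the scatter, and it shows that inhibition on the shared core responds to what this position carries. The exchange replaces one heavy atom with three and brings in a hydrogen-bond acceptor where fluoro is counted with none, but this single step cannot separate the two differences or show whether either one matters. Nothing measured here accounts for the lower number.

Among these compounds, with only one step at this position, it remains open whether the gain is particular to dimethylamino or would also appear with a primary amine, a methoxy group or a longer chain such as diethylamino. As far as these compounds go, it is also open whether dimethylamino would give a step of similar size at the place that holds chloro in compound 1, and whether a second group on the same ring would add to it.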